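The compounds below may be only part of what the source reports. "The series", "measured", "known", "first", "only" and "open" are said of these compounds alone.

Measured so far in a functional assay on NTUB1 cells (Homo sapiens) for cytotoxicity, read by MTT assay, with a stated time of 72 h; on this read-out lower numbers stand for stronger inhibition and higher numbers for weaker inhibition:
- compound 1 `CCOC(=O)c1ccc(/C=C/C(=O)c2cc(OC)ccc2OC)cc1`: 4490 nM
- compound 2 `CCCNC(=O)c1ccc(/C=C/C(=O)c2cc(OC)ccc2OC)cc1`: 2260 nM

Compound 2 and compound 1 lie within the scatter of each other, so neither can be ranked above the other. Compound 3 `COc1ccc(OC)c(C(=O)/C=C/c2ccc(C(=O)NC(C)C)cc2)c1` carries isopropyl in place of propyl on an amide-type nitrogen. Within the data shown here, the only measured step that bears on this is a 2.0-fold lower number from compound 1 to compound 2 (0.30 log units; within the scatter), propylamino in place of ethoxy on a carbonyl carbon. It lies within the scatter and does not compare propyl with isopropyl. No step beyond the scatter is therefore expected in this assay. The estimated value for compound 3 is 2400 nM, with an expected range of 900 nM to 6000 nM. This estimate amounts to an expected 1.1-fold higher number from compound 2 to compound 3 (0.03 log units; within the scatter).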

Compound 3, half-maximal inhibitory concentration: 1970 nM
Compound 3: middle estimate off by 1.2-fold (0.09 log units), on the high side; low and high end bracket the measured number.
By their numbers in this assay, from the lowest: compounds 3, 2 and 1 (each within the scatter of the next, the first and the last beyond it).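

In this assay, isopropyl in place of propyl on the amide-type nitrogen gives a step within the scatter (a 1.1-fold lower number from compound 2 to compound 3 (0.06 log units; within the scatter)), so the two chains cannot be told apart at this place. Isopropylamino in place of ethoxy on the carbonyl carbon gives the first step here beyond the scatter, though a modest one (a 2.3-fold lower number from compound 1 to compound 3 (0.36 log units; beyond the scatter)), while the propylamino step from compound 1 stays within it. No supporting evidence here accounts for either step. On these data alone, whether a longer chain, a cyclohexyl ring or a benzyl group on the amide-type nitrogen would set a compound apart from compound 3 remains open.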